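Notes on the step from compound 2 to compound 4

A few compounds are considered here, and "the series" means these few. Any claim that something is new, unique, unknown or untested is made for them only; others in the source may bear on it.

In an ADME assay on microsomes from liver (Rattus norvegicus) for metabolic stability, read by LC-MS, using NADPH, at 37 degrees C (on this read-out lower numbers stand for a shorter-lived compound and higher numbers for a longer-lived compound), the compounds read as follows:
- compound 1 `Cc1cc(C)c(-c2nc(CN3CCC(C(=O)NCCCN4C[C@H](C)C[C@H](C)C4)CC3)c(C)o2)c(C)c1` gives > 0.5 h as a limit
- compound 2 `CC[C@@H]1C[C@H](CC)CN(CCCNC(=O)C2CCN(Cc3nc(-c4ccccc4C)oc3C)CC2)C1` gives 0.0917 h as a number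
- compound 3 `Cc1oc(-c2c(Cl)cccc2Cl)nc1CN1CCC(C(=O)NCCCN2C[C@H](C)C[C@H](C)C2)CC1` gives 0.0483 h as a number

Compound 2 lies within the scatter of compound 3. The value of compound 1 is a limit.

Compound 4 `Cc1ccccc1-c1nc(CN2CCC(C(=O)NCCCN3[C@H](C)CCC[C@@H]3C)CC2)c(C)o1` follows from compound 2 by the change 2,6-dimethylpiperidin-1-yl in place of 3,5-diethylpiperidin-1-yl on a saturated chain carbon, three bonds along the chain from an amide-type nitrogen on a saturated chain carbon, three bonds along the chain from an amide-type nitrogen. Among the measured compounds shown here, the one measured step of an at least 10-fold lower number from compound 1 to compound 3 (1.01 log units; beyond the scatter) is large, but it puts 2,6-dichlorophenyl in place of 2,4,6-trimethylphenyl on an aromatic carbon and does not touch this place. For the measured compounds named here, no measured step bears directly on the change, so nothing beyond the scatter is expected in this assay and the expected step is a 1.4-fold higher number from compound 2 to compound 4 (0.15 log units; within the scatter) for now. For compound 4 the estimated half-life is 0.13 h with an expected range from 0.05 h to 0.4 h in this estimate.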

Compound 4, half-life: > 0.5 h
Compound 4: no number, only a limit (the forecaster's own chance of this, stated with the estimate: 8%); at least 3.8-fold (0.58 log units) between middle value and limit.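

In this assay, the place on a saturated chain carbon, three bonds along the chain from an amide-type nitrogen, now proves able to move the half-life, whereas the earlier step changed only an aromatic substituent. 2,6-Dimethylpiperidin-1-yl in place of 3,5-diethylpiperidin-1-yl gives an at least 5.4-fold higher number from compound 2 to compound 4 (0.73 log units; beyond the scatter). Compound 4 gives > 0.5 h, which is a limit, so the full size of this step stays unknown: the limit of > 0.5 h in this assay, at which 2 of the 4 values shown sit.

The step changes the alkyl groups and their ring positions together, and 2,6-diethylpiperidin-1-yl at this place would be needed to separate the two. From the compounds shown here alone, whether the step carries over to the 2,6-dichlorophenyl compounds remains open.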